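A few compounds are considered here, and "the series" means these few. Any claim that something is new, unique, unknown or untested is made for them only; others in the source may bear on it.

The series shares one core, seen in compound 1 `N#Cc1c(Nc2ccccc2F)nc(SCc2cn(Cc3ccccc3Cl)nn2)nc1-c1ccccc1`, which in a functional assay on B16-F10 cells (Mus musculus) for inhibition, read by MTT assay, with a stated time of 72 h (a lower number here means a stronger inhibitor, a higher number a weaker inhibitor), gives 5230 nM. Compound 3 `N#Cc1c(Nc2ccccc2F)nc(SCc2cn(Cc3ccc(Cl)cc3)nn2)nc1-c1ccccc1` carries 4-chlorophenyl in place of 2-chlorophenyl on the saturated chain carbon bound to the aromatic nitrogen. In this assay compound 3 reaches only a limit, > 64000 nM. That move is an at least 12-fold higher number from compound 1 to compound 3 (1.08 log units; beyond the scatter). Compound 2 `Cc1ccc(Cn2cc(CSc3nc(Nc4ccccc4C)c(C#N)c(-c4ccccc4)n3)nn2)cc1` also gives only a limit in this assay, > 64000 nM. So two of the three values sit at the limit of > 64000 nM in this assay, at which 2 of the 3 values shown sit, and compound 3 stands at that limit with no number of its own; it cannot be ranked against compound 2, and only compound 1 lies clearly inside the measured range.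

Compound 4 `Cc1ccc(Cn2cc(CSc3nc(Nc4ccccc4F)c(C#N)c(-c4ccccc4)n3)nn2)cc1` is the next one: methyl in place of chloro on an aromatic carbon. Among the compounds with values here, no measured step covers methyl against chloro on this aromatic carbon. Within the data shown here, the single measured step, from compound 1 to compound 3, concerned where the chloro sits rather than what sits there, and it was large. Compound 2, which also bears 4-methylbenzyl, sits at the limit. The expected step that the limit leaves unreadable from compound 3 to compound 4 is therefore none beyond the scatter. Compound 4 is estimated at 70000 nM, between 20000 nM and 250000 nM, and is expected most likely to come back once more as a limit.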

Compound 4, half-maximal inhibitory concentration: 16000 nM
Compound 4: middle estimate off by 4.4-fold (0.64 log units), on the high side; the whole stated range lies above it.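

The para carbon of the benzyl ring is not limited to one outcome: with methyl in place of chloro on this aromatic carbon, this assay gives an at least 4.0-fold lower number from compound 3 to compound 4 (0.60 log units; beyond the scatter), so a para substituent does not by itself put a compound at the limit, which the step from the 2-chlorophenyl to the 4-chlorophenyl compound had left possible. The 4-methylbenzyl group does not fix the outcome either, since fluoro in place of methyl on an aromatic carbon of the other ring gives an at least 4.0-fold lower number from compound 2 to compound 4 (0.60 log units; beyond the scatter), showing that this second site also matters in the series. Replacing 2-chlorophenyl with 4-methylphenyl gives a 3.1-fold higher number from compound 1 to compound 4 (0.49 log units; beyond the scatter), the only one of these steps joining two measured numbers, while the other two are bounds on their true size: the limit of > 64000 nM in this assay, at which 2 of the 4 values shown sit.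

Going by these compounds, it remains open whether the methyl result extends to a methoxy group, an amine or a longer chain on this para carbon. Also open, on these data alone, is whether 2-methylphenyl would match the 2-chlorophenyl of compound 1, and how far the two steps from the limit actually reach.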